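This account rests on a few compounds, and the source may have more. Where it says the series, first, only, none or still open, it means among the compounds named here.

Measured in a functional assay on SW480 cells (Homo sapiens) for cytotoxicity, read by MTT assay, with a stated time of 48 h; on this read-out lower numbers stand for stronger inhibition and higher numbers for weaker inhibition:
compound 1 `O=c1ccoc2cc(OCc3cn(Cc4ccc(F)cc4)nn3)ccc12` gives 11200 nM.
compound 2 `CC(C)(C)c1ccc(Cn2cc(COc3ccc4c(=O)ccoc4c3)nn2)cc1` gives 28800 nM.
compound 3 `C#CCOc1ccc2c(=O)ccoc2c1` gives > 100000 nM, which is a limit of the assay and not a number.

Compound 1 holds the lowest of the two numbers shown. Its nearest neighbour is compound 2, reached by a 2.6-fold higher number from compound 1 to compound 2 (0.41 log units; beyond the scatter), a modest step from tert-butyl in place of fluoro on an aromatic carbon. Compound 3 sits at the limit of > 100000 nM in this assay, at which 1 of the 3 values shown sits, so it sets no number to compare against.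

Compound 4 `N#Cc1cccc(Cn2cc(COc3ccc4c(=O)ccoc4c3)nn2)c1` is not yet measured. It differs from compound 1 by 3-cyanophenyl in place of 4-fluorophenyl on a saturated chain carbon bound to an aromatic nitrogen. Among the measured compounds shown here, no measured step changes the benzyl ring in this way; the only step that touches that ring is a 2.6-fold higher number from compound 1 to compound 2 (0.41 log units; beyond the scatter), which moved the number modestly and in the weaker direction. Given that the rest of the shared core is unchanged, the expected step is a 1.3-fold higher number from compound 1 to compound 4 (0.10 log units; within the scatter), likely within the scatter or only slightly beyond it. Compound 4 is therefore estimated at 14000 nM, with a range from 5000 nM to 40000 nM.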

Compound 4, half-maximal inhibitory concentration: > 100000 nM
Compound 4 ended at the assay's limit; the forecaster's own chance of this, stated with the estimate: 10%; at least 7.1-fold (0.85 log units) between middle value and limit.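

The benzyl group is not freely open to change: where tert-butyl in place of fluoro gave only a 2.6-fold higher number from compound 1 to compound 2 (0.41 log units; beyond the scatter), the change from 4-fluorobenzyl to 3-cyanobenzyl gave an at least 8.9-fold higher number from compound 1 to compound 4 (0.95 log units; beyond the scatter). In this assay, the value for compound 4 is a limit of the assay and not a number: the limit of > 100000 nM in this assay, at which 2 of the 4 values shown sit. The size of this step therefore has only a lower bound, so in this series a larger group is not what separates the compounds, as compound 2 carries the bulkier tert-butyl and still gives a number.

The names 4-fluorophenyl and 3-cyanophenyl differ in both the group and its ring number, so this single step cannot say whether the nitrile or its ring place accounts for the loss. Also open, from the compounds shown here alone, is whether a methoxy group, an amine or a carboxylic acid on this ring would give a number in this assay.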